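A few compounds are considered here, and "the series" means these few. Any claim that something is new, unique, unknown or untested is made for them only; others in the source may bear on it.

Measured compounds:
- compound 1, `COc1ccc(CN(C(=O)C2CC2)c2cc(OC)c(OC)c(OC)c2)cc1O`: 59 nM
- compound 2, `COc1ccc(CNc2cc(OC)c(OC)c(OC)c2)cc1C`: 56800 nM
- compound 3, `C/C=C/C(=O)N(Cc1ccc(OC)c(N)c1)c1cc(OC)c(OC)c(OC)c1`: 150 nM

In a functional assay on MGC-803 cells (Homo sapiens) for inhibition, read by MTT assay, with a stated time of 48 h (on this read-out lower numbers stand for stronger inhibition and higher numbers for weaker inhibition), compound 1 gives the lowest number of the three, so it is the strongest inhibitor here. Its nearest neighbour is compound 3, whose value in this assay is beyond the usual scatter from that of compound 1, and compound 2 is far weaker still. No pair among these three differs in only one place, so no single structural step can be read from the measured values alone.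

Compound 4, `COc1ccc(CN(C(=O)C=C(C)C)c2cc(OC)c(OC)c(OC)c2)cc1O`, is not yet measured. It differs from compound 1 in one place: 2-methylprop-1-en-1-yl in place of cyclopropyl on a carbonyl carbon. The rest of the molecule, including the shared core and the amide-type nitrogen, stays as it is. Among the measured compounds shown here, since no comparable step between measured compounds is available, the expectation rests on the closeness of compound 1 and compound 3, which both carry a carbonyl on that nitrogen and both give low numbers in this assay. The step from compound 1 to compound 4 is expected to be small, a 1.7-fold higher number from compound 1 to compound 4 (0.23 log units; within the scatter), leaning if anything toward a slightly weaker inhibition, and compound 4 is estimated to give about 100 nM in this assay, in a range from 35 nM to 300 nM.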

Compound 4, half-maximal inhibitory concentration: 320 nM
Estimate against measurement, compound 4: 3.2-fold (0.51 log units) below; measured number above the stated range.
By their numbers in this assay, from the lowest: compound 1; then compound 3; then compound 4; then compound 2.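

In this assay, among the compounds shown here, putting 2-methylprop-1-en-1-yl in place of cyclopropyl on the carbonyl carbon gives a 5.4-fold higher number from compound 1 to compound 4 (0.73 log units; beyond the scatter), the first single change that can be read. It shows that inhibition in these cells depends on which carbon group sits on this carbonyl, with the cyclopropyl compound giving the lower number. Neither group carries a hydrogen-bond donor, a hydrogen-bond acceptor or a net charge, so the step swaps a three-membered ring of carbon only for an open chain with a double bond, and no measurement at hand explains why the number rises.

This one step changes the ring, the carbon count and the double bond together, so the compounds shown leave open which of these goes with the weaker inhibition. Going by these compounds, a saturated 2-methylpropyl chain or a cyclobutyl ring on the same carbonyl carbon could help pull these apart, and it also remains open whether any group there can give a lower number than compound 1 at 59 nM.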